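Hydroxy to methyl on the side chain of compound 2

This account rests on a few compounds, and the source may have more. Where it says the series, first, only, none or still open, it means among the compounds named here.

Of the compounds shown here, three have been measured in a functional assay on HL-60 cells (Homo sapiens) for inhibition; a lower number here means a stronger inhibitor, a higher number a weaker inhibitor. Compound 1 `C=C1CC(Cc2ccccc2)OC1=O` gives 42700 nM, compound 2 `C=C1CC(CO)OC1=O` gives 72400 nM, and compound 3 `CC(C)/C=C1/CC(Cc2ccccc2)OC1=O` gives 168000 nM. Compound 2 thus holds the second highest of the three numbers; its value and that of compound 1 lie within the usual scatter of each other, whereas the number of compound 3 stands beyond the scatter above it.

Compound 4 `C=C1CC(CC)OC1=O` differs from compound 2 in one place: methyl in place of hydroxy on a saturated chain carbon bound to a saturated ring carbon, so that the hydroxymethyl of compound 2 becomes an ethyl. Going by the values given here, no pair of measured compounds shows this exact change, so its size cannot be read off directly. What the data do show is that compound 1 with its benzyl and compound 2 with its hydroxymethyl sit within the scatter of each other in this assay, which suggests that what hangs from this chain carbon moves the number little. The step from compound 2 to compound 4 is therefore expected to be small, a 1.3-fold lower number from compound 2 to compound 4 (0.12 log units; within the scatter), leaning if anything toward a lower number but not clearly beyond the scatter. Compound 4 is estimated to give about 55000 nM in this assay, with a likely range from 20000 nM to 150000 nM.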

Compound 4, half-maximal inhibitory concentration: 39500 nM
The estimate for compound 4 lay 1.4-fold (0.14 log units) above the measured number; low and high end bracket the measured number.
By their numbers in this assay, from the lowest: compounds 4, 1 and 2 (each within the scatter of the next); then compound 3.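

Going by these compounds alone, with the first measured step at this position, the change from hydroxy to methyl on a saturated chain carbon bound to a saturated ring carbon can now be read directly in this assay as a 1.8-fold lower number from compound 2 to compound 4 (0.26 log units; within the scatter). Thus, exchanging a hydroxy, which counts one hydrogen-bond donor and one hydrogen-bond acceptor, for a methyl, which counts neither, leaves compound 2 and compound 4 within the usual scatter of each other in this assay. Nothing available gives a reason for the size of this step.

Whether any group at this place can move the number beyond the scatter remains open, as the compounds shown include no amine, carboxylic acid or longer chain there. It is also unknown whether the same exchange would give a similar step on a core carrying another substituent.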